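Notes on compound 4 in the antiproliferative series

The source may hold more compounds than are shown below. What is called first, only, known or untested is meant among the compounds shown, and "the series" means these compounds.

Measured so far in a functional assay on MCF7 cells (Homo sapiens) for antiproliferative activity, read by MTT assay, with a stated time of 72 h; a higher number here means a weaker inhibitor, a lower number a stronger inhibitor:
compound 1, `CCOC(=O)c1cc(=O)c2cc(CSC(=S)N(C(C)C)C(C)C)ccc2o1`: > 25000 nM, which is a limit of the assay and not a number
compound 2, `CC(C)N(C(=S)SCc1cc(=O)c2ccccc2o1)C(C)C`: 31700 nM
compound 3, `CC(C)N(C(=S)SCc1coc2ccccc2c1=O)C(C)C`: > 30000 nM, which is a limit of the assay and not a number

Where compound 1 stands: only a limit is known for it, the one at the limit of > 25000 nM in this assay, at which 1 of the 3 values shown sits. Among the three values shown, compound 2 alone gives a number, and it lies close to the limits. Compound 3 sits at the other limit, (the limit of > 30000 nM in this assay, at which 1 of the 3 values shown sits). Within the data shown here, no step between two measured compounds that differ in one place is available in this set.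

Compound 4, `CCOC(=O)c1cc(=O)c2cc(CSC(=S)N3CCOCC3)ccc2o1`, differs from compound 1 by morpholin-4-yl in place of diisopropylamino on a thiocarbonyl carbon. With compound 1 known only as a limit, no direction can be read from the data for this change, so the step from compound 1 to compound 4 is expected as a step that the limit leaves unreadable from compound 1 to compound 4, that is, none beyond the scatter. In this assay compound 4 is therefore estimated at 30000 nM, with a range from 12000 nM to 80000 nM, and the assay is expected most likely to report only a limit again.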

Compound 4, half-maximal inhibitory concentration: > 25000 nM
Compound 4: a limit, no number; the forecaster's own chance of this, stated with the estimate: 70%; the middle value lies beyond the limit too.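

In this assay, compound 1 and compound 4 each give only a limit and not a number, so no step can be read for morpholin-4-yl in place of diisopropylamino: the limit of > 25000 nM in this assay, at which 2 of the 4 values shown sit.

The compounds shown leave open how far either group on the core of compound 1 separates in this assay.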